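The source may report more compounds than this note shows. Statements on the series, on what has been measured and on what is new or still open speak of the compounds shown alone.

The measured compounds and their values:

- compound 1, `COc1ccc(-c2cnc3nc(N)nc(N4CCN(C(=O)NCc5ccccc5)CC4)c3n2)cc1OC`: 18 nM
- compound 2, `CC(C)Oc1nc(N)nc2ncc(-c3ccc(C(F)(F)F)cc3)nc12`: > 10000 nM
- compound 3, `COc1ccc(-c2cnc3nc(N)nc(N4CCN(Cc5c(Cl)cccc5Cl)CC4)c3n2)cc1OC`: 7600 nM

In a functional assay on cells (T-cell, Homo sapiens) for inhibition (a higher number here means a weaker inhibitor, a lower number a stronger inhibitor), compound 1 gives 18 nM, the lowest of the two numbers recorded. The nearest number belongs to compound 3, and the change a 420-fold higher number from compound 1 to compound 3 (2.63 log units; beyond the scatter) is large. For compound 2 the assay reports only a limit, > 10000 nM; this is the limit of > 10000 nM in this assay, at which 1 of the 3 values shown sits, and it is not a number that can be compared directly.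

The unmeasured compound 4, `COc1ccc(-c2cnc3nc(N)nc(N4CCN(C(=O)NCc5ccc(F)cc5)CC4)c3n2)cc1OC`, keeps everything of compound 1 except one small change: fluoro in place of hydrogen on an aromatic carbon.

Among the compounds with values here, only one measured step exists, and it swaps the whole group on the amine nitrogen of the ring, 2,6-dichlorobenzyl in place of benzylcarbamoyl. That step says nothing about a single fluoro entering on the aromatic carbon para to a large group while the benzylcarbamoyl stays in place. Within the data shown here, no measured step therefore bears on the change from compound 1 to compound 4, and a shift of no more than the usual scatter is expected in this assay, in no particular direction.

Compound 4 is thus estimated to give 18 nM in this assay, with a plausible range from 7 nM to 45 nM, which means an expected step of no change at the digits printed from compound 1 to compound 4 (within the scatter).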

Compound 4, half-maximal inhibitory concentration: 37 nM
For compound 4 the middle estimate is 2.1-fold (0.31 log units) below the measured one; the range from low to high includes it.
By their numbers in this assay, from the lowest: compound 1; then compound 4; then compound 3. At a limit, above all of these: compound 2.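

In this assay, within the data shown here, the first direct look at this position comes from a single added atom: a 2.1-fold higher number from compound 1 to compound 4 (0.31 log units; beyond the scatter). The change is modest, so the aromatic carbon para to a large group accepts fluoro with only a small loss, and the step is still beyond the scatter, so even this small change registers in the assay. The other new step, a 210-fold lower number from compound 3 to compound 4 (2.31 log units; beyond the scatter), is large, and it shows that the wide gap between the carbamoyl compounds and the dichlorobenzyl compound survives the fluoro change, although nothing measured here explains the shift at the aromatic carbon.

On these data alone, how a chloro, a methoxy or an amine on this same carbon would compare stays open, as does whether fluoro on another carbon of this ring would give a similar small step. Compound 3 also differs from compound 4 both in the link to the ring nitrogen and in the groups on the benzene ring, so the compounds shown cannot say which of these two differences carries the large step.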